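The compounds below may be only part of what the source reports. "The series", "measured", "known", "first", "only" and "open" are said of these compounds alone.

In a physicochemical assay for solubility, in phosphate buffer, measured as kinetic solubility (a lower number here means a less soluble compound, a higher number a more soluble compound), compound 1 `CC(C)C(CC1C(=O)NC(=O)N1C)c1ccc(-c2ccc3cccc(F)c3c2)[nH]c1=O` gives 33600 nM. Compound 2 `Cc1cc(C(/C=C2\OC(=O)NC2=O)C(C)C)c(=O)[nH]c1-c1ccc2cccc(F)c2c1` gives 35700 nM, and compound 3 `CCC(/C=C1\OC(=O)NC1=O)(CC)c1ccc(-c2ccc3cccc(F)c3c2)[nH]c1=O` gives 32600 nM. The three numbers lie within the usual scatter of one another, so compound 1 stands level with the other two. No two of these compounds differ in one place only, so the series offers no measured single-change step.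

Compound 4 `C/C(=C1/OC(=O)NC1=O)C(c1ccc(-c2ccc3cccc(F)c3c2)[nH]c1=O)C(C)C` has not yet been measured in this assay. Relative to compound 1, the change is a group of 9 heavy atoms (5 carbon, 1 nitrogen, 3 oxygen; one five-membered non-aromatic ring with 2 hetero atoms) in place of a group of 9 heavy atoms (5 carbon, 2 nitrogen, 2 oxygen; one five-membered non-aromatic ring with 2 hetero atoms), on a saturated chain carbon bound to an aromatic carbon and a saturated chain carbon. Both groups have 9 heavy atoms and one five-membered non-aromatic ring with 2 hetero atoms. The ring that enters also occurs in compound 2 and compound 3. Compound 1 at 33600 nM lies within the scatter of compound 2 at 35700 nM and compound 3 at 32600 nM. However, neither compound isolates this change, so this support is indirect. The expected step, a 1.1-fold lower number from compound 1 to compound 4 (0.02 log units; within the scatter), is therefore none beyond the scatter, with no direction expected. For compound 4, the estimated value is 32000 nM, with an expected range of 17000 nM to 52000 nM.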

Compound 4, solubility: 17200 nM
The estimate for compound 4 lay 1.9-fold (0.27 log units) above the measured number, and the stated range covers the measured number.
By their numbers in this assay, from the lowest: compounds 4, 3, 1 and 2 (each within the scatter of the next, the first and the last beyond it).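

In this assay, the series now has its first measured single-change step, a 2.0-fold lower number from compound 1 to compound 4 (0.29 log units; within the scatter), and that step stays within the scatter. At this place, on a saturated chain carbon bound to an aromatic carbon and a saturated chain carbon, the (3-methyl-2,5-dioxoimidazolidin-4-yl)methyl group can therefore be exchanged for the entering group, which has the same heavy-atom count and also carries a five-membered non-aromatic ring with 2 hetero atoms, without a step beyond the scatter on the core of compound 1. No measurement at hand explains the size of this step.

This single pair does not show whether the same exchange would stay within the scatter on the cores of compound 2 or compound 3, which carry different substitution. It also leaves open how this assay would respond at this place to a group of a different type, such as a carboxylic acid, an amine or a longer open chain without a ring.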